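This account rests on a few compounds, and the source may have more. Where it says the series, first, only, none or still open, it means among the compounds named here.

Of the compounds shown here, three have been measured so far: compound 1 `CC(O)(C(=O)Nc1ccc(S(=O)(=O)c2cccc(F)c2)cc1)C(F)(F)F`, compound 2 `CC(O)(C(=O)Nc1ccc(S(=O)(=O)c2ccccc2)c(C#N)c1)C(F)(F)F` and compound 3 `CC(O)(C(=O)Nc1ccc(C#N)c(Sc2ccccc2)c1)C(F)(F)F`. In a functional assay (Cavia porcellus) with sulfonylurea receptors; K-ATP channels (Homo sapiens) as the target (on this read-out higher numbers stand for weaker inhibition and lower numbers for stronger inhibition), compound 1 gives 3400 nM, the lowest of the three numbers. Compound 2 gives 3800 nM, within the scatter of compound 1, while compound 3 gives 8300 nM, beyond it. Compound 4 `COc1cccc(S(=O)(=O)c2ccc(NC(=O)C(C)(O)C(F)(F)F)cc2)c1` has not yet been measured. It differs from compound 1 by methoxy in place of fluoro on an aromatic carbon, meta to a large group. Among the measured compounds shown here, no pair of measured compounds isolates this change, so nothing measured fixes its size. The step is expected to be small in this assay, likely none beyond the scatter, with no clear direction. For compound 4 the estimate is 3500 nM, between 1500 nM and 8000 nM. The expected step is a 1.0-fold higher number from compound 1 to compound 4 (0.01 log units; within the scatter).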

Compound 4, half-maximal inhibitory concentration: 16000 nM
Estimate against measurement, compound 4: 4.6-fold (0.66 log units) below; the whole stated range lies below it.
By their numbers in this assay, from the lowest: compounds 1 and 2 (each within the scatter of the next); then compounds 3 and 4 (each within the scatter of the next).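

The substituent at this aromatic carbon, meta to a large group, matters in this assay: 3-fluorophenyl to 3-methoxyphenyl gives a 4.7-fold higher number from compound 1 to compound 4 (0.67 log units; beyond the scatter), so inhibition weakens. Among the compounds shown here, this is the first single-place step, and it shows that the position is not indifferent to the group it carries. No measurement here accounts for the step.

Going by these compounds, whether the size of the group, its oxygen or another feature drives this remains open. On these data alone, how chloro, hydroxyl or an amine would read at this carbon also remains open.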